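A few compounds are considered here, and "the series" means these few. Any claim that something is new, unique, unknown or untested is made for them only; others in the source may bear on it.

Compound 1 `C=C1CC[C@@H]2[C@](C)(CO[Si](c3ccccc3)(c3ccccc3)C(C)(C)C)[C@H](OC(C)=O)CC[C@@]2(C)[C@@H]1C/C=C1/C(=O)OC[C@H]1O` and compound 2 `C=C1CC[C@@H]2[C@](C)(CO[Si](c3ccccc3)(c3ccccc3)C(C)(C)C)[C@H](OC(C)=O)CC[C@@]2(C)[C@@H]1C/C=C1/C(=O)OC[C@H]1OC(C)=O` share a core. In a functional assay on ASK cells (Rattus norvegicus) for cytotoxicity, read by sulforhodamine B assay (a lower number here means that less compound is needed, a higher number that more compound is needed for the effect), compound 1 gives 10.5 uM, and compound 2 gives 32.8 uM. The change between them, (acetyl in place of hydrogen on an oxygen on a saturated carbon), produced a 3.1-fold higher number from compound 1 to compound 2 (0.49 log units; beyond the scatter). Compound 3 `C=C1CC[C@@H]2[C@](C)(COC(C)=O)[C@H](O)CC[C@@]2(C)[C@@H]1C/C=C1/C(=O)OC[C@H]1O` has a different core; how the cores of compound 1 and compound 3 differ is not broken down here. In this assay compound 3 gives 16.7 uM. Compound 4 `C=C1CC[C@@H]2[C@](C)(COC(C)=O)[C@H](O)CC[C@@]2(C)[C@@H]1C/C=C1/C(=O)OC[C@H]1OC(C)=O` is not yet measured and differs from compound 3 by acetyl in place of hydrogen on an oxygen on a saturated carbon, the same change as from compound 1 to compound 2, at a place described in the same words. Because a 3.1-fold higher number from compound 1 to compound 2 (0.49 log units; beyond the scatter) was a modest step beyond the scatter, a step of similar size is expected, a 2.9-fold higher number from compound 3 to compound 4 (0.46 log units; beyond the scatter) in this assay. Compound 4 is accordingly estimated at 48 uM, expected to fall between 22 uM and 105 uM.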

Compound 4, concentration for half-maximal effect: 16.3 uM
Beside the measured number, compound 4's estimate is 2.9-fold (0.47 log units) above it; measured number below the stated range.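

In this assay, acetyl in place of hydrogen on an oxygen on a saturated carbon gives a 1.0-fold lower number from compound 3 to compound 4 (0.01 log units; within the scatter), so the step seen on the core of compound 1 does not recur on the core of compound 3. The size of this step therefore depends on the core in these two pairs: the same change on two cores in this assay, a 3.1-fold higher number (0.49 log units; beyond the scatter) from compound 1 to compound 2 and a 1.0-fold lower number (0.01 log units; within the scatter) from compound 3 to compound 4, 3.2-fold (0.51 log units) apart, beyond the scatter of two such steps. Going by these compounds alone, two pairs show only that the change does not carry over reliably between these cores; they do not show which difference between the cores is responsible, or how any third core would respond.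

Open, on these data alone, is how a longer acyl chain such as butanoyl, or an amine-bearing chain, on that oxygen would read on either core.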